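Amide nitrogen group swap in the phenylsulfone cyclopentane series

A few compounds are considered here, and "the series" means these few. Any claim that something is new, unique, unknown or untested is made for them only; others in the source may bear on it.

Measured so far:
compound 1 `N#CCNC(=O)[C@@H]1C[C@@H](S(=O)(=O)CC2CC2)C[C@H]1C(=O)N1CCOCC1`: 4510 nM
compound 2 `N#CC1(NC(=O)[C@@H]2C[C@@H](S(=O)(=O)c3ccccc3)C[C@H]2C(=O)N2CCOCC2)CCC1`: 236 nM
compound 3 `N#CC1(NC(=O)[C@@H]2C[C@@H](S(=O)(=O)c3ccccc3)C[C@H]2C(=O)N2CC3(COC3)C2)CC1`: 248 nM

In a functional assay on A20 cells (Mus musculus) for inhibition, with stated times of 1 h, 16 h and 24 h (a higher number here means a weaker inhibitor, a lower number a stronger inhibitor), compound 3 stands second highest of the three numbers; its nearest neighbour is compound 2, within the scatter, and the furthest is compound 1, beyond it. Compound 4 `N#CC1(NC(=O)[C@@H]2C[C@@H](S(=O)(=O)c3ccccc3)C[C@H]2C(=O)N2CCC2)CC1` is not yet measured. It differs from compound 3 by a group of 4 heavy atoms (3 carbon, 1 nitrogen; one four-membered non-aromatic ring with 1 hetero atom) in place of a group of 7 heavy atoms (5 carbon, 1 nitrogen, 1 oxygen; 2 four-membered non-aromatic rings with 1 hetero atom each), on a carbonyl carbon. Among the compounds with values here, no step between measured compounds changes a single place, so there is no direct anchor for this exchange. Compound 2 and compound 3 carry different groups on that carbonyl carbon and lie within the scatter of each other, which points to tolerance there. The step in this assay from compound 3 to compound 4 is expected to be small, in no definite direction, and within the scatter. Compound 4 is therefore estimated at 260 nM, with a range of 100 nM to 650 nM, meaning an expected step of a 1.0-fold higher number from compound 3 to compound 4 (0.02 log units; within the scatter).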

Compound 4, half-maximal inhibitory concentration: 44 nM
Estimate against measurement, compound 4: 5.9-fold (0.77 log units) above, and the stated range ends above it.
By their numbers in this assay, from the lowest: compound 4; then compounds 2 and 3 (each within the scatter of the next); then compound 1.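

Within the data shown here, the first single-place step shows that the group on this carbonyl carbon is not a neutral choice: in this assay, azetidin-1-yl in place of the group with two four-membered rings gives a 5.6-fold lower number from compound 3 to compound 4 (0.75 log units; beyond the scatter). Within this pair, the lower number goes with the smaller group, which has no hydrogen-bond acceptor. No measurement at hand accounts for the step. Open, from the compounds shown here alone, is whether a pyrrolidin-1-yl or dimethylamino group on that carbonyl carbon keeps the lower number, and whether the gain depends on the four-membered ring itself.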